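The source may hold more compounds than are shown below. What is called first, only, known or untested is meant among the compounds shown, and "the series" means these compounds.

Measured so far in a functional assay on HT-29 cells (Homo sapiens) for antiproliferative activity, read by sulforhodamine B assay, with a stated time of 48 h; a higher number here means a weaker inhibitor, a lower number a stronger inhibitor:
- compound 1 `CCc1ccccc1OS(=O)(=O)c1ccc(N2CCN(C)C2=O)cc1` gives 4600 nM
- compound 2 `CCN1CCN(c2ccc(S(=O)(=O)Oc3ccc(OC)cc3)cc2)C1=O` gives 60000 nM
- compound 3 `CCCN1CCN(c2ccc(S(=O)(=O)Oc3ccccc3CC)cc2)C1=O` gives > 100000 nM as a limit of the assay

Compound 3 has no number, only the limit (> 100000 nM) of the assay.

Compound 4 `CCCN1CCN(c2ccc(S(=O)(=O)Oc3cccc(C)c3)cc2)C1=O` keeps the rest of compound 3 and puts 3-methylphenyl in place of 2-ethylphenyl on an oxygen.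

Within the data shown here, the one measured step (an at least 21-fold higher number from compound 1 to compound 3 (1.33 log units; beyond the scatter)) changes the chain on the ring nitrogen and leaves the 2-ethylphenyl in place. Among the measured compounds shown here, no measured step changes the group on the oxygen alone. Compound 2 carries another group there, has a different chain as well, and still gives a number (60000 nM) inside the range of the assay.

Compound 4 keeps the chain of compound 3, so a return to the level of compound 1 is not expected. A further limit remains possible. The expected change is an at least 2.0-fold lower number from compound 3 to compound 4 (0.30 log units; that floor lies within the scatter) and points to a lower number, with its size uncertain. For compound 4 the estimated value is 50000 nM with an expected range from 10000 nM to 100000 nM.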

Compound 4, half-maximal inhibitory concentration: 65000 nM
Compound 4: middle estimate off by 1.3-fold (0.11 log units), on the low side; measured number inside the range.
By their numbers in this assay, from the lowest: compound 1; then compounds 2 and 4 (each within the scatter of the next). At a limit, above all of these: compound 3.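

With the chain of compound 3 held, 3-methylphenyl in place of 2-ethylphenyl on an oxygen gives a number inside the range of this assay (an at least 1.5-fold lower number from compound 3 to compound 4 (0.18 log units; that floor lies within the scatter)). Among these compounds, this is the first step that changes the group on this oxygen alone, and it shows that the chain of compound 3 does not by itself bring a compound to the limit. The size of the step remains a floor within the scatter, because one end of it is a limit: the limit of > 100000 nM in this assay, at which 1 of the 4 values shown sits.

Still open, on these data alone, is how other groups on this oxygen would read, such as a phenyl carrying an amine or a carboxylic acid. Also open, as far as these compounds go, is how 3-methylphenyl would read with the methyl on the ring nitrogen of compound 1 or with a longer chain such as butyl.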